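Hydroxylated pyrrolidine analogue of compound 2

The compounds below may be only part of what the source reports. "The series", "measured", "known", "first", "only" and "open" are said of these compounds alone.

Compound 2 `O=C(Nc1ccc(Oc2ccccc2)cc1)Nc1ccc2nn(CCN3CCCC3)cc2c1` stands highest of the two numbers in an in vitro assay on cells for displacement of a labelled ligand from melanin-concentrating hormone receptor 1 (Homo sapiens) (on this read-out higher numbers stand for weaker inhibition and lower numbers for stronger inhibition), where compound 2 gives 46 nM. Compound 1 `O=C(Nc1ccc(Oc2ccccc2)cc1)Nc1ccc2c(cnn2CCN2CCCCC2)c1` gives 5 nM in this assay, a lower number that lies beyond the scatter. Compound 3 `O=C(Nc1ccc(Oc2ccccc2)cc1)Nc1ccc2nn(CCN3CC[C@H](O)C3)cc2c1` differs from compound 2 by hydroxy in place of hydrogen on a saturated ring carbon. Within the data shown here, no measured pair shows this change, so no step beyond the scatter is expected in this assay in either direction. The step of a 1.1-fold higher number from compound 2 to compound 3 (0.04 log units; within the scatter) is expected to be small. Compound 3 is estimated at 50 nM, within 15 nM to 160 nM.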

Compound 3, half-maximal inhibitory concentration: 57 nM
Estimate against measurement, compound 3: 1.1-fold (0.06 log units) below; measured number inside the range.
By their numbers in this assay, from the lowest: compound 1; then compounds 2 and 3 (each within the scatter of the next).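

In this assay, the change from pyrrolidin-1-yl to 3-hydroxypyrrolidin-1-yl gives a 1.2-fold higher number from compound 2 to compound 3 (0.09 log units; within the scatter). Hydroxy is therefore tolerated on this saturated ring carbon, two ring bonds from the ring nitrogen, with no step beyond the scatter, at least for the single stereoisomer shown. Nothing available explains this result.

Going by these compounds, whether the opposite stereoisomer of the 3-hydroxypyrrolidin-1-yl group behaves the same way remains open. So does the outcome with a methoxy group, an amine or a carboxylic acid on this ring carbon.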